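A few compounds are considered here, and "the series" means these few. Any claim that something is new, unique, unknown or untested is made for them only; others in the source may bear on it.

Measured so far:
- compound 1, `CCCCCCNc1[nH]ccc2ncnc1-2`: > 9 mg/kg in a functional assay on the whole organism (Pleural cavity) with Rattus norvegicus as the target; on this read-out lower numbers stand for an effect already at smaller amounts and higher numbers for an effect only at larger amounts of compound
- compound 2, `OCCNc1[nH]ccc2ncnc1-2`: > 9 mg/kg in this assay

Both of these values are limits of this assay rather than measured numbers. For compound 1 the value > 9 mg/kg is such a limit. For compound 2 the value > 9 mg/kg is likewise a limit. Among the measured compounds shown here, the single step between the two, a step that the two limits leave unreadable from compound 1 to compound 2, therefore cannot be read. Compound 2 stands at the limit of > 9 mg/kg in this assay, at which 2 of the 2 values shown sit, and nothing places it more exactly.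

Compound 3, `CSc1[nH]ccc2ncnc1-2`, differs from compound 2 in one place: methylsulfanyl in place of (2-hydroxyethyl)amino on an aromatic carbon. For the measured compounds named here, the only measured step, a step that the two limits leave unreadable from compound 1 to compound 2, concerns another part of the molecule and is unreadable, so it gives neither a size nor a direction for this change. With nothing to lean on, the expected step is a step that the limit leaves unreadable from compound 2 to compound 3, not beyond the scatter and without a direction drawn from the data. For compound 3 in this assay the estimate is 15 mg/kg, within 5 mg/kg to 50 mg/kg, and a further limit is the most likely outcome.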

Compound 3, dose for half-maximal effect: 9 mg/kg
Compound 3: the middle estimate sits 1.7-fold (0.22 log units) above what was measured; measured number inside the range.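

In this assay, compound 3 is the only compound shown that carries a measured number rather than a limit, so this aromatic carbon next to the ring nitrogen can hold a group that gives a readable dose. Putting methylsulfanyl in place of (2-hydroxyethyl)amino gives a number no higher from compound 2 to compound 3 (the limit leaves the size open), so the change has a direction at most and no size that can be compared with the usual scatter. Compound 2 remains a limit, and this is as far as the comparison can go: the limit of > 9 mg/kg in this assay, at which 2 of the 3 values shown sit.

The compounds shown cannot separate the role of the sulfur atom from that of the smaller group, since methylsulfanyl has fewer heavy atoms than (2-hydroxyethyl)amino and also no hydrogen-bond donors. A methoxy group on the same carbon, or a longer chain on the sulfur such as ethylsulfanyl, would show whether the dose stays with that of compound 3 or moves away from it.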